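Dropping the nitro group from a weakly active thiazine

The compounds below may be only part of what the source reports. "The series", "measured", "known", "first", "only" and "open" are said of these compounds alone.

compound 1, `COc1ccc(C2(O)SC=C(C)n3c2noc3=O)cc1`, a limit of the assay in a functional assay on A2780/DX3 cells (Homo sapiens) for antiproliferative activity, read by MTT assay, with a stated time of 3 days; on this read-out lower numbers stand for stronger inhibition and higher numbers for weaker inhibition: > 100000 nM
compound 2, `CC1=CSC(O)(c2cccc([N+](=O)[O-])c2)c2noc(=O)n21`, a number in this assay: 129000 nM
compound 3, `CCCCCOC1(c2ccc(Cl)cc2)SC=C(C)n2c1noc2=O`, a limit of the assay in this assay: > 100000 nM

Compound 2 stands alone among the three as the only one that gives an actual number; the other two reach only (the limit of > 100000 nM in this assay, at which 2 of the 3 values shown sit). Even so, the number for compound 2 lies close to that limit, so all three compounds count as weak in this assay, and none can be ordered against the others.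

Compound 4, `CC1=CSC(O)(c2ccccc2)c2noc(=O)n21`, differs from compound 2 by hydrogen in place of nitro on an aromatic carbon. Within the data shown here, no pair of measured compounds shows this change, so the expectation rests on the whole set being weak and on the change being a small one. The step from compound 2 to compound 4 is expected to stay within the scatter, a 1.2-fold higher number from compound 2 to compound 4 (0.07 log units; within the scatter). For compound 4 the estimate in this assay is 150000 nM, expected between 60000 nM and 400000 nM, with a fair chance that only a limit is reported.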

Compound 4, half-maximal inhibitory concentration: > 100000 nM
Compound 4: a limit, no number; the forecaster's own chance of this, stated with the estimate: 60%; the middle value does not contradict the limit.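

In this assay compound 4 gives only a limit, > 100000 nM. Its steps from compound 2 and from compound 1 cannot be read. The compounds shown leave open how hydrogen, nitro and methoxy on the aromatic carbon rank against one another, and the values offer little to separate them: the limit of > 100000 nM in this assay, at which 3 of the 4 values shown sit.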